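Ester to ketone on the shared core: growth inhibition

The source may hold more compounds than are shown below. What is called first, only, known or untested is meant among the compounds shown, and "the series" means these compounds.

Measured so far:
compound 1 `C=C(C)[C@@H]1CC=C(Cn2cc(COc3cccc(C4NC(=O)NC(C)=C4C(=O)OCC)c3)nn2)CC1` gives a limit only: > 100000 nM
compound 2 `C=C(C)[C@@H]1CC=C(Cn2cc(COc3ccccc3C3NC(=O)NC(C)=C3C(=O)OCC)nn2)CC1` gives a limit only: > 100000 nM
compound 3 `C=C(C)[C@@H]1CC=C(Cn2cc(COc3cc(C4NC(=O)NC(C)=C4C(=O)OCC)ccc3OC)nn2)CC1` gives a limit only: > 100000 nM

In a functional assay on PC-3 cells (Homo sapiens) for inhibition, read by sulforhodamine B assay, with a stated time of 48 h (on this read-out lower numbers stand for stronger inhibition of growth and higher numbers for weaker inhibition of growth), compound 3 reaches only the limit of the measurement and no number. Compound 1 likewise sits at the limit. Compound 2 sits at the limit as well. Going by the values given here, the one step between measured neighbours, a step that the two limits leave unreadable from compound 1 to compound 3, cannot be read in size or direction because of the limit of > 100000 nM in this assay, at which 3 of the 3 values shown sit.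

Compound 4 `C=C(C)[C@@H]1CC=C(Cn2cc(COc3cc(C4NC(=O)NC(C)=C4C(C)=O)ccc3OC)nn2)CC1` differs from compound 3 in a single place: methyl in place of ethoxy on a carbonyl carbon. Among the compounds with values here, no measured step concerns the carbonyl carbon, and none of the three measured compounds supplies a number from which a size could be taken. The starting point for compound 4 is itself only a limit.

Compound 4 is therefore expected to lie around 150000 nM, with a range of 40000 nM to 600000 nM. The step that the limit leaves unreadable from compound 3 to compound 4 is expected to be none beyond the scatter, and a further limit rather than a number is the more likely outcome.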

Compound 4, concentration for total growth inhibition: > 100000 nM
Compound 4 ended at the assay's limit; the forecaster's own chance of this, stated with the estimate: 75%; the middle value is on the limit's open side.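

The step from compound 3 to compound 4 cannot be read in size or direction, because both compounds stop at a limit: the limit of > 100000 nM in this assay, at which 4 of the 4 values shown sit.

The compounds shown leave open how ethoxycarbonyl and acetyl compare on the shared core in this assay, and whether any compound on this core gives a measurable number.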